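A few compounds are considered here, and "the series" means these few. Any claim that something is new, unique, unknown or untested is made for them only; others in the source may bear on it.

Compound 1, `Cn1c(=O)c2nc(-c3ccc(Cl)cc3)[nH]c2n(C)c1=O`: in an assay for binding affinity to adenosine receptor A1 (Bos taurus) (a lower number here means a stronger inhibitor, a higher number a weaker inhibitor), compound 1 gives 0.8 nM.
Compound 2, `CCn1c(=O)c2nc(-c3ccc(S(=O)(=O)NCCCN(C)C)cc3)[nH]c2n(CC)c1=O`: in this assay compound 2 gives 1.6 nM.
Compound 3, `Cn1c(=O)c2nc(-c3ccc(Cl)cc3N)[nH]c2n(C)c1=O`: in this assay compound 3 gives 0.35 nM.

Compound 3 stands at the lowest of the three numbers in this assay, and each of its gaps to the other two is beyond the usual scatter, so it is the strongest binder among them. Within the data shown here, the one measured step, a 2.3-fold lower number from compound 1 to compound 3 (0.36 log units; beyond the scatter), shows that adding an amino group on the aromatic ring of compound 1 helped modestly.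

Compound 4, `Cc1ccc(-c2nc3c(=O)n(C)c(=O)n(C)c3[nH]2)c(N)c1`, keeps that amino group and changes one other thing: methyl in place of chloro on an aromatic carbon. Among the measured compounds shown here, no measured pair shows this exchange, so the single known step gives only indirect guidance. Both groups are single heavy atoms without donors or acceptors, so nothing beyond the scatter is expected in either direction for this assay.

Compound 4 is estimated at 0.5 nM in this assay, with a range from 0.15 nM to 1.8 nM, which corresponds to an expected step of a 1.4-fold higher number from compound 3 to compound 4 (0.15 log units; within the scatter).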

Compound 4, half-maximal inhibitory concentration: 10 nM
Compound 4: the middle estimate sits 20-fold (1.30 log units) below what was measured; measured number outside the range, above it.
By their numbers in this assay, from the lowest: compound 3; then compounds 1 and 2 (each within the scatter of the next); then compound 4.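

In this assay, methyl in place of chloro on an aromatic carbon turns out not to be a neutral exchange: it gives a 29-fold higher number from compound 3 to compound 4 (1.46 log units; beyond the scatter), a large weakening, even though each group counts one heavy atom, no hydrogen-bond donors or acceptors and no net charge. Those counts therefore do not tell the two groups apart at this place, meta to an amino group and para to a large group, and in this pair chloro gives the stronger inhibitor. Nothing available explains why the two groups differ so much here.

On these data alone, it remains open whether other groups at this position, such as fluoro, bromo or methoxy, would stay close to chloro or fall towards methyl. As far as these compounds go, it is also open whether the same exchange would cost as much on compound 1, which lacks the amino group.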